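The compounds below may be only part of what the source reports. "The series", "measured", "known", "first", "only" and "open" are said of these compounds alone.

Compound 1 `CC1CN(c2nc(-c3ccc4ccccc4c3)nn2-c2ccccc2)C2(C=CC(=O)C=C2)O1`: 320 nM
Compound 2 `CC1OC2(C=CC(=O)C=C2)N(c2nc(-c3ccc4ccccc4c3)nn2-c2ccccc2)C1=O`: 310 nM
Compound 3 `O=C1C=CC2(C=C1)OCC(=O)N2c1nc(-c2ccc3c(c2)OCCO3)nn1-c1ccccc1`: 170 nM

All three values come from a functional assay on A549 cells (Homo sapiens) for antiproliferative activity, with a stated time of 5 days; on this read-out higher numbers stand for weaker inhibition and lower numbers for stronger inhibition. Compound 3, at 170 nM, lies within the usual scatter of both compound 1 and compound 2, so the three cannot be ranked on these numbers. Going by the values given here, compound 3 differs from each of the other two in more than one place, so no measured pair isolates the effect of a single change.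

The next compound is compound 4 `O=C1C=CC2(C=C1)OCC(=O)N2c1nc(-c2cccc(Cl)c2)nn1-c1ccccc1`, which has 3-chlorophenyl in place of 2,3-dihydro-1,4-benzodioxin-6-yl on an aromatic carbon. The rest of compound 3 stays the same. Compound 2, at 310 nM, carries a different group on that same carbon from compound 3, at 170 nM, yet the two remain within the scatter of each other. That gives only indirect support for expecting a modest effect here. Among the compounds with values here, no measured compound carries the entering group, so the direction is a tentative guess. The expected change is a 1.6-fold higher number from compound 3 to compound 4 (0.22 log units; within the scatter), a slightly higher number that may not exceed the scatter. For compound 4 the estimate is 280 nM, with an expected range of 90 nM to 850 nM.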

Compound 4, half-maximal inhibitory concentration: 25.2 nM
For compound 4 the middle estimate is 11-fold (1.05 log units) above the measured one; measured number outside the range, below it.
By their numbers in this assay, from the lowest: compound 4; then compounds 3, 2 and 1 (each within the scatter of the next).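

Going by these compounds alone, this is the first pair of compounds that differ in one place only, and so the first direct reading of this aromatic carbon on the five-membered ring with 3 nitrogen: in this assay there is a 6.7-fold lower number from compound 3 to compound 4 (0.83 log units; beyond the scatter), a step beyond the scatter. The earlier compounds shown here all lay within the scatter of their neighbours and gave no sign that a change here could matter, whereas this swap of 2,3-dihydro-1,4-benzodioxin-6-yl for 3-chlorophenyl shows that the group on this carbon can shift the number clearly. Nothing shown here gives a measured reason for the shift.

Within the data shown here, the single step also joins two changes, the loss of the six-membered non-aromatic ring with its two oxygen atoms and the arrival of the chlorine, so it cannot say which of them matters. As far as these compounds go, how a plain phenyl group would read at this carbon remains open, as does the effect of a methoxy group or a bromine atom in place of the chlorine, and whether the same swap would give a similar step on the core of compound 1.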